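A few compounds are considered here, and "the series" means these few. Any claim that something is new, unique, unknown or untested is made for them only; others in the source may bear on it.

The series rests on a shared core, seen in compound 1 with structure `COC(=O)c1c(Nc2ccccc2)sc(C(=O)c2ccc(C)cc2)c1C`, which in a functional assay, with a stated time of 150 min, tested at 15 ug/mL (on this read-out lower numbers stand for a weaker effect and higher numbers for a stronger effect at the one concentration tested), gives 4.59%. Compound 2, `COC(=O)c1c(Nc2ccc(C)cc2)sc(C(=O)c2ccc(C)cc2)c1C`, is reported in this assay as "not active" (no number reported), with no number attached. Compound 3, `COC(=O)c1c(Nc2ccc(F)cc2)sc(C(=O)c2ccc(C)cc2)c1C`, likewise comes back from this assay as "not active" (no number reported), again without a number. Compound 3 therefore stands without a single value of its own, and it shares that standing with one further member of the set; only compound 1 carries a figure, and that figure is small.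

Compound 4, `COC(=O)c1c(Nc2ccc(Cl)cc2)sc(C(=O)c2ccc(C)cc2)c1C`, has not yet been measured in this assay. It differs from compound 3 in one place: chloro in place of fluoro on an aromatic carbon. Among the measured compounds shown here, no step between two measured compounds in this set is recorded, so the size of the change from compound 3 to compound 4 in this assay has no direct precedent. Given that compound 3 shows "not active" (no number reported) and that even compound 1 reaches only 4.59%, no movement beyond the usual scatter is expected in either direction. Compound 4 is accordingly estimated to give 3% in this assay, with a range from 0% to 12%, and a sizeable chance that only a limit is reported.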

Compound 4, a percentage reported as activity, at one concentration (the size of the read-out at that concentration, not a potency): "not active" (no number reported)
Compound 4 has no reported number here; the estimate stays without a comparison.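

In this assay, among the compounds shown here, compound 3 gives "not active" (no number reported) and compound 4 gives "not active" (no number reported), so no step between these two compounds can be read. Nothing available bears on this result. The compounds shown leave open how large any difference between fluoro and chloro at this place would be.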